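A few compounds are considered here, and "the series" means these few. Any claim that something is new, unique, unknown or untested is made for them only; others in the source may bear on it.

The series rests on the core of compound 1, `O=C1C(=O)N(CCOc2ccc(Oc3ccccc3)cc2)c2ccc(OC(F)(F)F)cc21`, which in an assay on isolated protein for positive allosteric modulation of muscarinic acetylcholine receptor M5 (Homo sapiens) (on this read-out lower numbers stand for smaller maximal responses and higher numbers for larger maximal responses), gives 93%. Compound 2, `O=C1C(=O)N(CCOc2ccccc2)c2ccc(OC(F)(F)F)cc21`, carries hydrogen in place of phenoxy on an aromatic carbon, and in this assay compound 2 gives 91%. That step, a number 2 percentage points lower from compound 1 to compound 2 (within the scatter), stays within the scatter. Compound 3, `COc1ccc(CN2C(=O)C(O)(c3ccc(F)nc3)c3cc(OC(F)(F)F)ccc32)cc1`, is built differently, and in this assay compound 3 gives 74%. Among the three measured numbers compound 2 stands second highest: compound 1 lies close to it, within the scatter, while compound 3 lies lower by a gap beyond the scatter.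

Compound 4, `COc1ccc(OCCN2C(=O)C(=O)c3cc(OC(F)(F)F)ccc32)cc1`, has not yet been measured. It differs from compound 2 by methoxy in place of hydrogen on an aromatic carbon, the methoxy sitting on an aromatic carbon of a six-membered aromatic ring of carbon only, para to a large group. Among the compounds with values here, the only measured step that bears on this change is the one on the same ring, a number 2 percentage points lower from compound 1 to compound 2 (within the scatter), where hydrogen in place of phenoxy left the response unchanged within the scatter. A methoxy entering that ring is therefore expected to move the response little, if at all. Compound 4 is expected to show a step of a number 1 percentage points lower from compound 2 to compound 4 (within the scatter). Compound 4 is accordingly estimated at about 90% in this assay, within a range from 78% to 102%.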

Compound 4, largest response reached (Emax), in percent of the reference or control that the assay uses: 89%
Estimate against measurement, compound 4: 1 percentage points above; low and high end bracket the measured number.
By their numbers in this assay, from the lowest: compound 3; then compounds 4, 2 and 1 (each within the scatter of the next).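

Compound 4 gives this position a third occupant: on the six-membered aromatic ring of carbon only, para to a large group, the series now holds hydrogen, methoxy and phenoxy, all read in this assay. Adding methoxy to the bare ring gives a number 2 percentage points lower from compound 2 to compound 4 (within the scatter), and the comparison with the larger group, with methyl in place of phenyl on the same oxygen, gives a number 4 percentage points lower from compound 1 to compound 4 (within the scatter). The earlier compounds shown here showed only that removing phenoxy made no difference beyond the scatter, whereas these steps show that a small group without a ring also sits at this position with no such difference, so the maximal response of compound 1, compound 2 and compound 4 does not separate them by what occupies it.

As far as these compounds go, whether an amine or a carboxylic acid at this position, or a longer chain on the oxygen in place of methyl, would also stay within the scatter remains open. Also open, from the compounds shown here alone, is whether the same change would read alike on the differently built compound 3. Nothing shown here gives a reason for these small steps.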